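Dimethoxyphenoxy tail exchanged for benzyl on the chain

A few compounds are considered here, and "the series" means these few. Any claim that something is new, unique, unknown or untested is made for them only; others in the source may bear on it.

The measured compounds and their values in an in vitro functional assay on HEK ts201 cells for antagonist activity at Neuronal acetylcholine receptor; alpha4/beta2 (Homo sapiens), read by fluorescence and calcium flux; on this read-out higher numbers stand for weaker inhibition and lower numbers for stronger inhibition:
compound 1, `COc1ccc(OCCCCCN2CCCC(COC(=O)c3ccccc3N3C(=O)CC(C)C3=O)C2)cc1OC`, 8320 nM
compound 2, `CC1CC(=O)N(c2ccccc2C(=O)OCC2CCCN(CCCCOc3ccc(Cl)c(Cl)c3)C2)C1=O`, 12300 nM
compound 3, `COc1cccc(OCCCCCN2CCCC(COC(=O)c3ccccc3N3C(=O)CC(C)C3=O)C2)c1OC`, 8710 nM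

Compound 3 sits among these three numbers without separating from either neighbour: the step of a 1.4-fold lower number from compound 2 to compound 3 (0.15 log units; within the scatter), and the step of a 1.0-fold higher number from compound 1 to compound 3 (0.02 log units; within the scatter). Both lie within the scatter, so no ordering among the three can be claimed.

Compound 4, `CC1CC(=O)N(c2ccccc2C(=O)OCC2CCCN(CCCCCCc3ccccc3)C2)C1=O`, differs from compound 3 by benzyl in place of 2,3-dimethoxyphenoxy on a saturated chain carbon, five bonds along the chain from an amine nitrogen in a ring. Among the measured compounds shown here, two measured steps touch the same region of the molecule. The step of a 1.5-fold higher number from compound 1 to compound 2 (0.17 log units; within the scatter) exchanged one aryloxy tail for another and shortened the chain by one link, and the step of a 1.4-fold lower number from compound 2 to compound 3 (0.15 log units; within the scatter) reversed such an exchange; neither moved the number beyond the scatter. Neither step removed the ether oxygen altogether, so the exact change to compound 4 has no measured precedent, but the tolerance shown by compound 1, compound 2 and compound 3 toward tail variation suggests a step of no more than the scatter.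

Compound 4 is therefore expected to give 9500 nM in this assay, with a range of 3500 nM to 26000 nM. The estimated step of a 1.1-fold higher number from compound 3 to compound 4 (0.04 log units; within the scatter) is expected to fall within the usual scatter.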

Compound 4, half-maximal inhibitory concentration: 29500 nM
Compound 4: middle estimate off by 3.1-fold (0.49 log units), on the low side; the measured number lies above the stated range.
By their numbers in this assay, from the lowest: compounds 1, 3 and 2 (each within the scatter of the next); then compound 4.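

In this assay, among the compounds shown here, the tail on the chain is less forgiving than the earlier compounds suggested: the all-carbon tail of compound 4 gives a 3.4-fold higher number from compound 3 to compound 4 (0.53 log units; beyond the scatter), and the other two comparisons agree, with a 3.5-fold higher number from compound 1 to compound 4 (0.55 log units; beyond the scatter) and a 2.4-fold higher number from compound 2 to compound 4 (0.38 log units; beyond the scatter), all modest but beyond the scatter. For the compounds shown here, compounds 1, 2 and 3 all carry an aryl ether tail and stay within the scatter of one another, whether the ring bears two methoxy groups or two chlorines, so compound 4, with no oxygen in its tail, is the only one that stands apart and the only compound that weakens inhibition measurably, though this contrast rests on that single compound. No available evidence accounts for the loss of inhibition.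

The exchange removes the ether oxygen and the two methoxy groups together, so the compounds shown cannot assign the shift to either change alone. An unsubstituted phenoxy tail would separate the two, while a methoxy-bearing phenyl ring on an all-carbon chain would test the same question from the other side.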